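The source may hold more compounds than are shown below. What is called first, only, known or untested is meant among the compounds shown, and "the series" means these compounds.

Measured so far:
compound 1, `Cc1c(/N=C/c2ccc(N(C)C)cc2)c(=O)n(-c2ccccc2)n1C`: 832000000 nM
compound 2, `CCOc1cccc(/C=N/c2c(C)n(C)n(-c3ccccc3)c2=O)c1`: 933000000 nM

Both numbers come from a functional assay on HCT-116 cells (Homo sapiens) for cytotoxicity, read by MTT assay, with a stated time of 72 h; on this read-out higher numbers stand for weaker inhibition and lower numbers for stronger inhibition. In this assay compound 1 gives 832000000 nM and compound 2 gives 933000000 nM; the two lie within the usual scatter of each other, so nothing separates compound 1 from compound 2, and both sit at very weak inhibition. For the measured compounds named here, no step between measured compounds that differ in one place is available, so the series gives no measured guide to how a change on the six-membered aromatic ring of carbon only moves the number.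

The next compound, compound 3, `COc1ccc(/C=N/c2c(C)n(C)n(-c3ccccc3)c2=O)cc1`, is to be measured in this assay. Relative to compound 1 the change is methoxy in place of dimethylamino on an aromatic carbon, set para to a large group on that ring. With compound 1 at 832000000 nM and compound 2 at 933000000 nM both far into the weak range, the expectation is no step beyond the scatter, in either direction, for compound 3.

For compound 3 the estimate in this assay is 900000000 nM, with a range from 400000000 nM to 2000000000 nM, meaning an expected step of a 1.1-fold higher number from compound 1 to compound 3 (0.03 log units; within the scatter).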

Compound 3, half-maximal inhibitory concentration: 575000000 nM
The estimate for compound 3 lay 1.6-fold (0.19 log units) above the measured number; low and high end bracket the measured number.
By their numbers in this assay, from the lowest: compounds 3, 1 and 2 (each within the scatter of the next).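

In this assay, for the compounds shown here, methoxy in place of dimethylamino on an aromatic carbon, para to a large group, gives a 1.4-fold lower number from compound 1 to compound 3 (0.16 log units; within the scatter) and so provides the first one-place comparison, with no effect that can be separated from the scatter. Compound 1 and compound 3 lie together at very weak inhibition, and on this read-out the two groups, each with 0 hydrogen-bond donors and 1 hydrogen-bond acceptor, cannot be told apart. No evidence bears on this result.

On these data alone, whether any group at this place can bring the number out of the very weak range remains open; a carboxylic acid or a longer chain in place of methoxy would test this. Also open, as far as these compounds go, is whether a change elsewhere on the shared core would move the number at all.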